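The source may report more compounds than this note shows. Statements on the series, on what has been measured and on what is new or still open speak of the compounds shown alone.

In a functional assay on HCT-116 cells (Homo sapiens), read by MTT assay, with a stated time of 72 h (a lower number here means a stronger inhibitor, a higher number a weaker inhibitor), compound 1 `CSc1ncnc2c1c(-c1ccoc1)cn2[C@@H]1O[C@H](CO)[C@@H](O)[C@H]1O` gives 40 nM. Compound 2 `CSc1ncnc2c1c(-c1ccsc1)cn2[C@@H]1O[C@H](CO)[C@@H](O)[C@H]1O` gives > 20000 nM, which is a limit and not a number. Compound 3 `CNc1ncnc2c1c(-c1ccoc1)cn2[C@@H]1O[C@H](CO)[C@@H](O)[C@H]1O` gives > 20000 nM, again a limit and not a number, so it stands at the limit of > 20000 nM in this assay, at which 2 of the 3 values shown sit. Compound 4 `CNc1ncnc2c1c(-c1ccsc1)cn2[C@@H]1O[C@H](CO)[C@@H](O)[C@H]1O` carries thiophen-3-yl in place of furan-3-yl on an aromatic carbon. Going by the values given here, two measured steps bear on this. The same swap gave a large loss, an at least 500-fold higher number from compound 1 to compound 2 (2.69 log units; beyond the scatter), and methylamino in place of methylsulfanyl gave an equally large one, an at least 500-fold higher number from compound 1 to compound 3 (2.69 log units; beyond the scatter). Compound 4 carries both changes, so no recovery is expected, and the expected step, a step that the limit leaves unreadable from compound 3 to compound 4, stays within the scatter. For compound 4 the estimated value is 25000 nM, with an expected range of 10000 nM to 60000 nM.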

Compound 4, half-maximal inhibitory concentration: > 20000 nM
Compound 4: a limit, no number; the forecaster's own chance of this, stated with the estimate: 90%; the middle value lies beyond the limit too.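

No step can be read from compound 2 or compound 3 to compound 4, since all three give only a limit: the limit of > 20000 nM in this assay, at which 3 of the 4 values shown sit.

The compounds shown leave open whether furan-3-yl and thiophen-3-yl differ at all when methylamino is present.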